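Swapping Cyclopentyl on a Carbonyl Carbon

This account rests on a few compounds, and the source may have more. Where it says the series, first, only, none or still open, it means among the compounds named here.

Within the data shown here, in a physicochemical assay for lipophilicity, read by HPLC, measured as chromatographic lipophilicity, at pH 7.4 (a lower number here means a more polar compound, a higher number a more lipophilic compound), compound 1 `O=C(C1CCCC1)N1N=CCC1c1ccccc1` gives 5.4 and stands lowest of the two numbers so far. Compound 2 `CC1=NN(C(=O)C(C)(C)C)[C@H](c2ccccc2)C1` gives 6.4 and stands higher, beyond the scatter. Among the measured compounds shown here, compound 3 `CC(C)(CO)C(=O)N1N=CCC1c1ccccc1` carries 1-(hydroxymethyl)-1-methylethyl in place of cyclopentyl on a carbonyl carbon, and the change 1-(hydroxymethyl)-1-methylethyl in place of cyclopentyl on a carbonyl carbon has no counterpart among the measured compounds. A fall in this assay beyond the scatter is expected, and the estimated step of a number 1.90 log units lower from compound 1 to compound 3 (beyond the scatter) rests on the structural change alone. Compound 3 is expected at 3.5 within an estimated range of 2.8 to 4.2 once measured.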

Compound 3, distribution coefficient: 3.4
The estimate for compound 3 lay 0.10 log units above the measured number; measured number inside the range.
By their numbers in this assay, from the lowest: compound 3; then compound 1; then compound 2.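

On a carbonyl carbon, 1-(hydroxymethyl)-1-methylethyl in place of cyclopentyl gives a number 2.00 log units lower from compound 1 to compound 3 (beyond the scatter) in this assay and shows that this position answers strongly to this change. Both groups count 5 heavy atoms, so the step comes with no change in that count, while the ring is lost and an oxygen, a hydrogen-bond donor and a hydrogen-bond acceptor enter. No supporting measurement bears on why the number moves this far. The compounds shown leave open how an open carbon chain such as isobutyl, without oxygen, would compare. They also leave open how a methoxymethyl group or an amine would read here.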